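Hydroxy to 3-bromopropyl on the shared core

This account rests on a few compounds, and the source may have more. Where it says the series, first, only, none or still open, it means among the compounds named here.

Compound 1 `CN1CCN(CCCCCOc2c(Br)cc(Br)cc2Oc2ccc(Br)cc2Br)CC1`: 49.1 ug/mL
Compound 2 `OCCCOc1c(Br)cc(Br)cc1Oc1ccc(Br)cc1Br`: 32.3 ug/mL

Among the measured compounds shown here, in a functional assay on U-937 cells (Homo sapiens) for cytotoxicity, read by MTT assay, with a stated time of 24 h (on this read-out lower numbers stand for stronger inhibition and higher numbers for weaker inhibition), only two numbers are available, and the one measured step between them is a 1.5-fold lower number from compound 1 to compound 2 (0.18 log units; within the scatter). For the measured compounds named here, compound 2 therefore stands within the scatter of the only other measured compound.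

Compound 3 `BrCCCCCCOc1c(Br)cc(Br)cc1Oc1ccc(Br)cc1Br` has not yet been measured. It carries 3-bromopropyl in place of hydroxy on a saturated chain carbon, three bonds along the chain from an oxygen on an aromatic ring. Going by the values given here, the one exchange measured at this place, between compound 1 at 49.1 ug/mL and compound 2 at 32.3 ug/mL, stayed within the scatter. Among the compounds with values here, no measured compound carries the entering group, so this single step is weak guidance. No step beyond the scatter is expected in this assay. The expected change is a 1.1-fold higher number from compound 2 to compound 3 (0.03 log units; within the scatter). Compound 3 is estimated at 35 ug/mL, with an expected range of 15 ug/mL to 80 ug/mL.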

Compound 3, half-maximal inhibitory concentration: 33.8 ug/mL
Beside the measured number, compound 3's estimate is 1.0-fold (0.02 log units) above it; the range from low to high includes it.
By their numbers in this assay, from the lowest: compounds 2, 3 and 1 (each within the scatter of the next).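

In this assay, 3-bromopropyl in place of hydroxy gives a 1.0-fold higher number from compound 2 to compound 3 (0.02 log units; within the scatter), so this place accepts a change from a group with a hydrogen-bond donor and acceptor to one with neither, and the step stays within the scatter. Bromomethyl in place of 4-methylpiperazin-1-yl gives a 1.5-fold lower number from compound 1 to compound 3 (0.16 log units; within the scatter), which is also within the scatter, so the three chain ends shown now all lie within the scatter of one another. No evidence beyond these numbers bears on the result.

The compounds shown leave open whether a carboxylic acid or a primary amine at the chain end, or a chain longer than 6-bromohexyl, would give a step beyond the scatter in this assay. On these data alone, whether any change on this chain can do so also remains open.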